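Two protected nucleosides and a third awaiting measurement

A few compounds are considered here, and "the series" means these few. Any claim that something is new, unique, unknown or untested is made for them only; others in the source may bear on it.

Values in a functional assay on HEL cells (Homo sapiens); a higher number here means that more compound is tolerated, a lower number that less compound is tolerated:
- compound 1 `Cc1cn([C@@H]2O[C@H](CO[Si](C)(C)C(C)(C)C)[C@@]3(OS(=O)(=O)C=C3NCC(=O)C(=O)N3CCC3)[C@H]2O[Si](C)(C)C(C)(C)C)c(=O)n(C)c1=O`: 84400 nM
- compound 2 `COC(=O)NC1=CS(=O)(=O)O[C@@]12[C@@H](CO[Si](C)(C)C(C)(C)C)O[C@@H](n1cc(C)c(=O)n(C)c1=O)[C@@H]2O[Si](C)(C)C(C)(C)C`: > 200000 nM (a limit of the assay, not a number)
- compound 3 `COC(=O)CC(=O)NC1=CS(=O)(=O)O[C@@]12[C@@H](CO[Si](C)(C)C(C)(C)C)O[C@@H](n1cc(C)c(=O)n(C)c1=O)[C@@H]2O[Si](C)(C)C(C)(C)C`: not yet measured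

Compound 2 has no exact place on the scale of this assay, since all that is reported for it is the limit of > 200000 nM in this assay, at which 1 of the 2 values shown sits. Compound 3 differs from it by (methoxycarbonyl)methyl in place of methoxy on a carbonyl carbon. Among the compounds with values here, only one measured step bears on this change: an at least 2.3-fold higher number from compound 1 to compound 2 (0.37 log units; beyond the scatter). That step is a different replacement on the same amine nitrogen, so it offers only a loose guide. Its size suggests a modest move toward a lower number in this assay, although compound 3 could also remain at the limit. The expected step is an at least 1.3-fold lower number from compound 2 to compound 3 (0.12 log units; that floor lies within the scatter). For compound 3 the estimated value is 150000 nM, with an expected range from 70000 nM to 200000 nM.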

Compound 3, half-maximal cytotoxic concentration: 29000 nM
Compound 3: middle estimate off by 5.2-fold (0.71 log units), on the high side; measured number outside the range, below it.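

In this assay, replacing methoxy with (methoxycarbonyl)methyl on a carbonyl carbon gives an at least 6.8-fold lower number from compound 2 to compound 3 (0.83 log units; beyond the scatter), so this position responds clearly to a change that leaves the amide-type nitrogen in place and only extends the group on its carbonyl. Set against the other substituted amine, the new group also gives a 2.9-fold lower number from compound 1 to compound 3 (0.46 log units; beyond the scatter), which places compound 3 lowest of the three and shows that less compound is tolerated with ((methoxycarbonyl)methyl)carbonyl on the amine nitrogen than with (((azetidin-1-yl)carbonyl)carbonyl)methyl. The step from compound 2 can be read only as a floor, because compound 2 has a limit and not an exact number: the limit of > 200000 nM in this assay, at which 1 of the 3 values shown sits.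

Going by these compounds, whether the lower number follows from the longer chain or from the terminal ester stays open, and a plain propyl chain or a carboxylic acid on that carbonyl carbon would separate the two. All three compounds share the rest of the core, so the compounds shown also leave open whether the same change would have a similar effect on a core without the silyl groups.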